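The source may report more compounds than this note shows. Statements on the series, on what has been measured and on what is new or still open speak of the compounds shown alone.

In a functional assay on MCF7 cells (Homo sapiens) for cytotoxicity, read by sulforhodamine B assay, with a stated time of 72 h (a lower number here means a stronger inhibitor, a higher number a weaker inhibitor), compound 1 (`O=C(Nc1ccc(Nc2ncnc3c2cnn3-c2ccccc2)cc1)Nc1cccc(Br)c1`) gives 36300 nM. Within the data shown here, compound 2 (`Cc1ccccc1NC(=O)Nc1ccc(Nc2ncnc3c2cnn3-c2ccc(Cl)cc2)cc1`) gives 3150 nM, so compound 1 has the higher of the two numbers so far, and the gap between them is beyond the scatter. Compound 3 (`O=C(Nc1cccc(Cl)c1)c1ccc(Nc2ncnc3c2cnn3-c2ccccc2)cc1`) carries (3-chlorophenyl)carbamoyl in place of ((3-bromophenyl)carbamoyl)amino on an aromatic carbon, para to a large group: (3-chlorophenyl)carbamoyl in place of ((3-bromophenyl)carbamoyl)amino on an aromatic carbon. Among the measured compounds shown here, no measured step shows what this change does in this assay, so only a moderate fall in the number is expected, a 2.4-fold lower number from compound 1 to compound 3 (0.38 log units; beyond the scatter). That expectation leaves compound 3 within the span the two measured numbers mark out. For compound 3 the estimated value is 15000 nM, with an expected range from 4000 nM to 50000 nM.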

Compound 3, half-maximal inhibitory concentration: 1120 nM
Beside the measured number, compound 3's estimate is 13-fold (1.13 log units) above it; the measured number lies below the stated range.
By their numbers in this assay, from the lowest: compound 3; then compound 2; then compound 1.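

In this assay, (3-chlorophenyl)carbamoyl in place of ((3-bromophenyl)carbamoyl)amino on this aromatic carbon gives a 32-fold lower number from compound 1 to compound 3 (1.51 log units; beyond the scatter), so the number responds strongly to the group held at this position. The change alters the connecting unit and swaps bromine for chlorine at once, and this single step cannot separate the two. Nothing measured here accounts for the size of the step. From the compounds shown here alone, it remains open how much of the step belongs to each part of the change, and how a carboxylic acid or an amine at this position would read.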